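The compounds below may be only part of what the source reports. "The series", "measured", "known", "first", "only" and "open" are said of these compounds alone.

Measured compounds: compound 1 `COc1ccc(C)cc1NC(=O)CSc1nnc(-c2ccoc2C)n1Cc1ccco1`, 15.9 nM; compound 2 `Cc1occc1-c1nnc(SCC(=O)Nc2cccc(Cl)c2)n1Cc1ccco1`, 63.1 nM.

In a functional assay on CHO cells for antagonist activity at Orexin receptor type 2 (Homo sapiens), read by FLIPR and calcium flux (a higher number here means a weaker inhibitor, a lower number a stronger inhibitor), compound 2 gives the higher of the two numbers, with compound 1 the nearer and lower. Compound 3 `Cc1occc1-c1nnc(SCC(=O)Nc2ccc(N(C)C)cc2)n1Cc1ccco1` is not yet measured; it differs from compound 2 by 4-(dimethylamino)phenyl in place of 3-chlorophenyl on an amide-type nitrogen. Going by the values given here, the only step that bears on a change of the aryl group on the amide-type nitrogen is a 4.0-fold higher number from compound 1 to compound 2 (0.60 log units; beyond the scatter), a modest shift. A similar or smaller move, in either direction, is therefore expected from compound 2 to compound 3, a 1.3-fold lower number from compound 2 to compound 3 (0.10 log units; within the scatter). Compound 3 is estimated at 50 nM, between 15 nM and 200 nM.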

Compound 3, inhibition constant: 158 nM
Compound 3: middle estimate off by 3.2-fold (0.50 log units), on the low side; low and high end bracket the measured number.
By their numbers in this assay, from the lowest: compound 1; then compound 2; then compound 3.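

In this assay the aryl group on the amide-type nitrogen responds to a second change, with a 2.5-fold higher number from compound 2 to compound 3 (0.40 log units; beyond the scatter) and a 9.9-fold higher number from compound 1 to compound 3 (1.00 log units; beyond the scatter). Both 3-chlorophenyl and 4-(dimethylamino)phenyl therefore give higher numbers than 2-methoxy-5-methylphenyl, which leaves compound 1 as the strongest inhibitor of the three. No measurement shown here accounts for these differences. Still open, on these data alone, is whether a pyridine ring or a carboxylic acid on the phenyl ring would match compound 1, and whether 3-(dimethylamino)phenyl would behave like 4-(dimethylamino)phenyl.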